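Swapping the Ring on the Sulfonamide Nitrogen

The source may hold more compounds than are shown below. What is called first, only, known or untested is meant among the compounds shown, and "the series" means these compounds.

Measured compounds in an assay on CHO cells for displacement of a labelled ligand from prostaglandin E2 receptor EP1 subtype (Homo sapiens); a lower number here means a stronger inhibitor, a higher number a weaker inhibitor:
- compound 1 `CCc1ccccc1N(CC(=O)NCc1ccc(Cl)cc1)S(=O)(=O)c1ccc(C)cc1`: 10 nM
- compound 2 `Cc1ccc(S(=O)(=O)N(CC(=O)NCc2ccc(Cl)cc2)c2cccnc2C)cc1`: 200 nM
- compound 3 `Cc1ccc(S(=O)(=O)N(CC(=O)NCc2ccc(Cl)cc2)c2cccc(C)n2)cc1`: < 1000 nM (a limit of the assay, not a number)

Going by these compounds, compound 3 stands only at a limit: its value in this assay is a threshold that was not passed, so its exact position is unknown. Compound 4 `CCn1nccc1N(CC(=O)NCc1ccc(Cl)cc1)S(=O)(=O)c1ccc(C)cc1` differs from compound 3 in a single place: 1-ethyl-1H-pyrazol-5-yl in place of 6-methylpyridin-2-yl on a sulfonamide nitrogen.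

Of the measured steps, only one is readable. The change from a phenyl bearing an ethyl group to a methyl-bearing pyridyl on the same nitrogen gave a 20-fold higher number from compound 1 to compound 2 (1.30 log units; beyond the scatter), a clear loss. The steps a step that the limit leaves unreadable from compound 1 to compound 3 and a step that the limit leaves unreadable from compound 2 to compound 3 cannot be sized, as the limit of < 1000 nM in this assay, at which 1 of the 3 values shown sits, shows. Compound 4 carries a five-membered ring with an ethyl on nitrogen, so its position is uncertain; the weakening seen in a 20-fold higher number from compound 1 to compound 2 (1.30 log units; beyond the scatter) suggests a smaller ring is tolerated less well than the ethylphenyl of compound 1. Compound 4 is therefore expected to land near 150 nM, within 20 nM to 1000 nM, and the expected step is a step that the limit leaves unreadable from compound 3 to compound 4.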

Compound 4, inhibition constant: 158 nM
Compound 4: middle estimate off by 1.1-fold (0.02 log units), on the low side; the measured number falls inside the stated range.
By their numbers in this assay, from the lowest: compound 1; then compounds 4 and 2 (each within the scatter of the next).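

The 1-ethyl-1H-pyrazol-5-yl group of compound 4 and the 2-methylpyridin-3-yl group of compound 2 cannot be told apart in this assay, with a 1.3-fold lower number from compound 2 to compound 4 (0.10 log units; within the scatter). Compared with the 2-ethylphenyl group, the pyrazole ring gives a 16-fold higher number from compound 1 to compound 4 (1.20 log units; beyond the scatter), so the large loss on this sulfonamide nitrogen is no longer seen with a six-membered pyridine ring alone. Compound 3 stands at a limit of the assay, so neither of its steps to compound 4 or from the other compounds can be read: the limit of < 1000 nM in this assay, at which 1 of the 4 values shown sits.

The compounds shown do not separate the ring nitrogens from ring size or from the change of ethyl to methyl. Going by these compounds, how a 2-methylphenyl or a 1-methyl-1H-pyrazol-5-yl group would fare on this nitrogen remains open.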